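Homologation of the Ring Amine Substituent in a Tracheal Assay

A few compounds are considered here, and "the series" means these few. Any claim that something is new, unique, unknown or untested is made for them only; others in the source may bear on it.

Measured compounds:
Compound 1 `CO[C@@]12CCN(C)C[C@H]1[C@H](c1ccccc1)C(C#N)=C(N)O2`: 19800 nM
Compound 2 `CCN1CC[C@@]2(OC)OC(N)=C(C#N)[C@@H](c3ccccc3)[C@@H]2C1`: 23400 nM
Compound 3 `CCN1CC[C@@]2(OC)OC(N)=C(C#N)[C@@H](c3ccc(Br)cc3)[C@@H]2C1`: 13200 nM

In a functional assay on trachea (Cavia porcellus) (a higher number here means a weaker inhibitor, a lower number a stronger inhibitor), compound 1 gives 19800 nM. Compound 2 carries methyl in place of hydrogen on a saturated chain carbon bound to an amine nitrogen in a ring, and the step is a 1.2-fold higher number from compound 1 to compound 2 (0.07 log units; within the scatter). Compound 3 adds a bromo group, giving a 1.8-fold lower number from compound 2 to compound 3 (0.25 log units; within the scatter). The difference between the cores of compound 1 and compound 3 is not broken down here.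

Compound 4 `CCCN1CC[C@@]2(OC)OC(N)=C(C#N)[C@@H](c3ccc(Br)cc3)[C@@H]2C1` is not yet measured. It differs from compound 3 by methyl in place of hydrogen on a saturated chain carbon, two bonds along the chain from an amine nitrogen in a ring. This is the same kind of change as that from compound 1 to compound 2, but the place differs: there the methyl entered on a carbon bound to the amine nitrogen, here two bonds along the chain from it. Because the earlier step was a 1.2-fold higher number from compound 1 to compound 2 (0.07 log units; within the scatter), a similarly small step is expected in this assay, estimated as a 1.1-fold higher number from compound 3 to compound 4 (0.03 log units; within the scatter). Compound 4 is thus expected to give about 14000 nM, between 6000 nM and 35000 nM.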

Compound 4, half-maximal inhibitory concentration: 19400 nM
The estimate for compound 4 lay 1.4-fold (0.14 log units) below the measured number, within the range that was stated.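

In this assay, extending ethyl to propyl on the amine nitrogen gave a 1.5-fold higher number from compound 3 to compound 4 (0.17 log units; within the scatter). Set beside the earlier methyl step, this change carried from one core to the other without a difference that could be told apart: the same change on two cores in this assay, a 1.2-fold higher number (0.07 log units; within the scatter) from compound 1 to compound 2 and a 1.5-fold higher number (0.17 log units; within the scatter) from compound 3 to compound 4, 1.2-fold (0.09 log units) apart, within the scatter of two such steps. Among the compounds shown here, this shows only that the step stayed small on both cores; it does not show that the two steps are equal, since the methyl entered at a different place on the chain in each, nor that the result holds on any other core.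

The compounds shown leave open how a butyl chain, a branched chain or a benzyl group on the amine nitrogen would read in this assay. They also leave open whether a chloro or methoxy group on the aromatic ring would alter the size of this step.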